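The source may hold more compounds than are shown below. What is called first, only, known or untested is meant among the compounds shown, and "the series" means these compounds.

In this series three compounds share one core and differ only in the aryl group on a saturated ring carbon. Compound 1 `COc1ccc(C2C(C#N)=C(N)N(c3cc(OC)c(OC)c(OC)c3)C3=C2C(=O)CC(C)(C)C3)cc1` gives 0% in a functional assay on Ehrlich cells (Mus musculus) for cytotoxicity, tested at 10 ug/mL; on this read-out lower numbers stand for a weaker effect and higher numbers for a stronger effect at the one concentration tested. Compound 2 `COc1cc(N2C(N)=C(C#N)C(c3ccc(OC)c4ccccc34)C3=C2CC(C)(C)CC3=O)cc(OC)c1OC` gives 10% in this assay, and compound 3 `COc1cc(N2C(N)=C(C#N)C(c3ccc(C)cc3)C3=C2CC(C)(C)CC3=O)cc(OC)c1OC` gives 30%. Compound 3 therefore stands highest of the three, its step from compound 2 being a number 20 percentage points higher from compound 2 to compound 3 (beyond the scatter) and from compound 1 being a number 30 percentage points higher from compound 1 to compound 3 (beyond the scatter), while the step of a number 10 percentage points higher from compound 1 to compound 2 (within the scatter) lies within the scatter.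

Compound 4 `COc1cc(N2C(N)=C(C#N)C(c3ccccc3Cl)C3=C2CC(C)(C)CC3=O)cc(OC)c1OC` is not yet measured. It differs from compound 3 in one place: 2-chlorophenyl in place of 4-methylphenyl on a saturated ring carbon. Within the data shown here, all three measured steps concern the aryl group at this same position, and their sizes range from within the scatter to a modest gain; none of them introduces a chlorine, so no measured step points to a direction for compound 4. Given that every aryl change here has moved the read-out by a modest amount at most, the step of a number 10 percentage points lower from compound 3 to compound 4 (within the scatter) is expected to be small and of uncertain sign. Compound 4 is therefore estimated to give 20% in this assay, within a range from 0% to 45%.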

Compound 4, a percentage reported as activity, at one concentration (the size of the read-out at that concentration, not a potency): 10%
Beside the measured number, compound 4's estimate is 10 percentage points above it; the range from low to high includes it.
By their numbers in this assay, from the lowest: compounds 1, 2 and 4 (each within the scatter of the next); then compound 3.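

At this saturated ring carbon, the aryl group's substitution matters beyond the scatter: in this assay, 2-chlorophenyl in place of 4-methylphenyl gives a number 20 percentage points lower from compound 3 to compound 4 (beyond the scatter), the first downward step from compound 3 in the series. The other two new steps do not separate 2-chlorophenyl from the earlier aryl groups, with no change at the digits printed from compound 2 to compound 4 (within the scatter) for 4-methoxynaphthalen-1-yl and a number 10 percentage points higher from compound 1 to compound 4 (within the scatter) for 4-methoxyphenyl, so among these four compounds only the 4-methylphenyl group of compound 3 stands apart, while compounds 1, 2 and 4 lie within the scatter of one another. No available evidence bears on why 4-methylphenyl stands apart from the other three aryl groups.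

Since 2-chlorophenyl and 4-methylphenyl differ both in the group carried and in where it sits on the aromatic ring, this single step cannot show which of the two differences matters. On these data alone, it also remains open how an unsubstituted phenyl, or an amine or a carboxylic acid on the phenyl ring, would compare with compound 3 at this position.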